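A few compounds are considered here, and "the series" means these few. Any claim that something is new, unique, unknown or untested is made for them only; others in the source may bear on it.

Measured in a functional assay on HT29-AK cells (Homo sapiens) for cytotoxicity, read by MTT assay, with a stated time of 48 h; on this read-out higher numbers stand for weaker inhibition and lower numbers for stronger inhibition:
compound 1 `Fc1cccc(-c2nc(Nc3ccc(Cl)cc3)c3cc(F)ccc3n2)c1`: 40300 nM
compound 2 `Fc1cccc(-c2nc(Nc3cccc(Br)c3)c3cc(F)ccc3n2)c1`: > 50000 nM (a limit)
compound 3 `Oc1cccc(Nc2nc(-c3cccc(F)c3)nc3ccc(F)cc23)c1`: > 50000 nM (a limit)

Compound 3 gives > 50000 nM, which is a limit and not a number. The same limit holds for compound 2, so (the limit of > 50000 nM in this assay, at which 2 of the 3 values shown sit). Only compound 1 has a measured number.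

Compound 4 `Nc1ccc(Nc2nc(-c3cccc(F)c3)nc3ccc(F)cc23)cc1` differs from compound 3 as follows: 4-aminophenyl in place of 3-hydroxyphenyl on a nitrogen on an aromatic ring. In words, this is 4-aminophenyl in place of 3-hydroxyphenyl on a nitrogen on an aromatic ring.

Changes at this same place have given an at least 1.2-fold higher number from compound 1 to compound 2 (0.09 log units; that floor lies within the scatter) and an at least 1.2-fold higher number from compound 1 to compound 3 (0.09 log units; that floor lies within the scatter). Both floors lie within the scatter. The remaining change gave a step that the two limits leave unreadable from compound 2 to compound 3. Among the measured compounds shown here, no measured step therefore points to a real shift, and none beyond the scatter is expected in this assay. The step expected here is an at least 1.4-fold lower number from compound 3 to compound 4 (0.15 log units; that floor lies within the scatter). Compound 4 may also reach only the limit. For compound 4 the estimated value is 35000 nM, with an expected range of 12000 nM to 70000 nM.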

Compound 4, half-maximal inhibitory concentration: > 50000 nM
Compound 4 was reported as a limit (the forecaster's own chance of this, stated with the estimate: 45%); middle value at least 1.4-fold (0.15 log units) away from the limit.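

In this assay compound 4 gives > 50000 nM, which is a limit. Amino in place of chloro on an aromatic carbon gives an at least 1.2-fold higher number from compound 1 to compound 4 (0.09 log units; that floor lies within the scatter), so this change shows no real shift. Among the compounds shown here, the steps from compound 3 and compound 2 to compound 4 cannot be read, and 4-aminophenyl joins 3-bromophenyl and 3-hydroxyphenyl as a third group on this nitrogen that gives no measured number, leaving compound 1 as the only compound with one: the limit of > 50000 nM in this assay, at which 3 of the 4 values shown sit.

As far as these compounds go, it remains open whether a morpholine, a carboxylic acid or a longer alkyl chain on this phenyl ring would give a number clearly lower than that of compound 1. From the compounds shown here alone, the response to a change elsewhere on the shared core, such as a methoxy group in place of a ring fluorine, also remains open.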